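A few compounds are considered here, and "the series" means these few. Any claim that something is new, unique, unknown or untested is made for them only; others in the source may bear on it.

Measured compounds in an assay on CHO cells for displacement of a labelled ligand from adenosine receptor A1 (Homo sapiens), read by scintillation counting, tested at 10 uM; on this read-out lower numbers stand for less inhibition and higher numbers for more inhibition at the one concentration tested (going by the name of the read-out):
compound 1, `CC(C)Cc1csc(N)c1C(=O)c1ccc(Cl)cc1`, which gives 1%
compound 2, `Cc1sc(N)c(C(=O)c2ccc(Cl)cc2)c1-c1ccccc1`, which gives 1%
compound 3, `CC(C)(C)Cc1c(-c2cccnc2)sc(N)c1C(=O)c1ccc(Cl)cc1`, which gives 1%

All three compounds share a core in which an amino group and a substituted benzoyl group sit on a five-membered aromatic ring with one sulfur. In this assay compound 3 stands level with compounds 1 and 2 at the digits reported: the nearest of the two is compound 1, with no change at the digits reported, and the furthest is compound 2, again with no change at the digits reported, both within the usual scatter. None of the three shows more than a trace of displacement in this assay.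

The next compound is compound 4, `CC(C)(C)Cc1c(-c2ccc(Cl)c(Cl)c2)sc(N)c1C(=O)c1ccc(Cl)cc1`, which is unmeasured. It differs from compound 3 in one place:

3,4-dichlorophenyl in place of pyridin-3-yl on an aromatic carbon

The place is on an aromatic carbon of the five-membered aromatic ring with one sulfur, next to the ring sulfur and next to the ring atom that bears the neopentyl group. For the measured compounds named here, no step between measured compounds is available that would show what exchanging one ring at this position does. Given that compound 3 gives 1% and compounds 1 and 2 sit at the same level, the step from compound 3 to compound 4 is expected to be a number 2 percentage points higher from compound 3 to compound 4 (within the scatter), that is, none beyond the scatter. Compound 4 is therefore estimated to give 3% in this assay, with a range from 0% to 15%.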

Compound 4, a percentage reported as inhibition, at one concentration (the size of the read-out at that concentration, not a potency): 1%
For compound 4 the middle estimate is 2 percentage points above the measured one, and the stated range covers the measured number.
By their numbers in this assay, from the lowest: compounds 1, 2, 3 and 4 (each within the scatter of the next).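

For the compounds shown here, this is the only step in the set that exchanges one ring for another on an aromatic carbon next to the ring sulfur, and in this assay putting 3,4-dichlorophenyl in place of pyridin-3-yl gives no change at the digits printed from compound 3 to compound 4 (within the scatter). The entering ring is of carbon only, with 8 heavy atoms against 6 and 0 hydrogen-bond acceptors against 1, so at this position and at the one concentration tested, swapping the ring nitrogen for a carbon-only ring bearing two chlorines leaves the read-out within the scatter. No measurement shown here bears on why the read-out stays at this level.

With both compounds at the floor of the read-out, the step cannot say whether this exchange would matter in a compound that displaces more of the labelled ligand. Also open, on these data alone, is whether an amine or a carboxylic acid on the ring at this position, or a longer chain in place of the neopentyl group, would give any displacement at all.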